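Hydroxyphenyl in place of chlorophenyl on the imine carbon

The source may hold more compounds than are shown below. What is called first, only, known or untested is meant among the compounds shown, and "the series" means these compounds.

Among the compounds with values here, compound 1 `CCCCCCCCCCCCCCNC(=O)[C@H](CO)/N=C/c1ccc(Cl)cc1` gives 27500 nM in a functional assay on cells (Homo sapiens) for cytotoxicity, read by MTT assay, with a stated time of 24 h (on this read-out higher numbers stand for weaker inhibition and lower numbers for stronger inhibition), the lowest of the two numbers known, while compound 2 `CCCCCCCCCCCCCCNC(=O)[C@H](CO)/N=C/c1ccc(C)cc1` gives 102000 nM. Within the data shown here, the single measured step, a 3.7-fold higher number from compound 1 to compound 2 (0.57 log units; beyond the scatter), shows that a change on the aromatic ring can move the number beyond the scatter. Compound 3 `CCCCCCCCCCCCCCNC(=O)[C@H](CO)/N=C/c1cccc(O)c1` differs from compound 1 by 3-hydroxyphenyl in place of 4-chlorophenyl on a carbon with a double bond to nitrogen. Among the measured compounds shown here, no measured step joins these two groups directly, so only the size of that step guides expectation, with a modest weakening judged more likely. Compound 3 is therefore expected to give 50000 nM, between 15000 nM and 150000 nM. That estimate means an expected step of a 1.8-fold higher number from compound 1 to compound 3 (0.26 log units; within the scatter).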

Compound 3, half-maximal inhibitory concentration: 32600 nM
Compound 3: middle estimate off by 1.5-fold (0.19 log units), on the high side; low and high end bracket the measured number.
By their numbers in this assay, from the lowest: compounds 1 and 3 (each within the scatter of the next); then compound 2.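

In this assay, 3-hydroxyphenyl in place of 4-chlorophenyl on a carbon with a double bond to nitrogen gives a 1.2-fold higher number from compound 1 to compound 3 (0.07 log units; within the scatter) and so does not separate from the chloro compound. Set against 4-methylphenyl, the same group gives a 3.1-fold lower number from compound 2 to compound 3 (0.50 log units; beyond the scatter), which leaves 4-methylphenyl as the one group of the three that stands apart. Nothing shown separates the hydroxyl from its place on the ring, and how 4-hydroxyphenyl, 3-chlorophenyl or a phenyl carrying a carboxylic acid would read stays open. No measurement at hand gives a reason for these numbers.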